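This account rests on a few compounds, and the source may have more. Where it says the series, first, only, none or still open, it means among the compounds named here.

Measured compounds:
- compound 1 `CC(=O)Nc1ccc(S(=O)(=O)NNC(=O)c2cccnc2Nc2ccc(Cl)cc2)cc1`: 29500 nM
- compound 2 `O=C(NNS(=O)(=O)c1ccc(F)cc1)c1cccnc1Nc1ccc(Cl)cc1Cl`: 14800 nM

Of the compounds shown here, two share a core and have been tested in a functional assay on PC-3 cells (Homo sapiens) for antiproliferative activity; a higher number here means a weaker inhibitor of growth, a lower number a stronger inhibitor of growth. Compound 1 gives 29500 nM in this assay, and compound 2 gives 14800 nM. Within the data shown here, of these two numbers, the one for compound 1 is not separated from that of compound 2: the gap between them lies within the usual scatter of such measurements, so nothing can be said about which is the stronger inhibitor. Among the measured compounds shown here, no single-point step between measured compounds is available. Compound 2 differs from compound 1 in more than one place.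

Compound 3 `O=C(NNS(=O)(=O)c1ccc(Cl)cc1Cl)c1cccnc1Nc1ccc(Cl)cc1` has not yet been measured in this assay. It differs from compound 1 in one place: 2,4-dichlorophenyl in place of 4-acetamidophenyl on a sulfonyl sulfur. With no measured step of this kind to lean on, the expectation rests only on the two numbers shown, and the step is expected to be small, perhaps towards a lower number, but not clearly beyond the scatter. Compound 3 is therefore estimated at 15000 nM, within a range of 5000 nM to 45000 nM, which corresponds to an expected step of a 2.0-fold lower number from compound 1 to compound 3 (0.29 log units; within the scatter).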

Compound 3, concentration for 50% growth inhibition: 23400 nM
Compound 3: middle estimate off by 1.6-fold (0.19 log units), on the low side; the measured number falls inside the stated range.
By their numbers in this assay, from the lowest: compounds 2, 3 and 1 (each within the scatter of the next).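

In this assay, replacing 4-acetamidophenyl with 2,4-dichlorophenyl on a sulfonyl sulfur whose other neighbour is a sulfonamide nitrogen gives a 1.3-fold lower number from compound 1 to compound 3 (0.10 log units; within the scatter), so compound 1 and compound 3 cannot be told apart. Among these compounds, this is the first direct reading at this position, since the earlier pair differed in more than one place and could not isolate any single change. Here a group with a hydrogen-bond donor, a hydrogen-bond acceptor and a double bond outside the aromatic ring gives way to one with two chlorines and no donor or acceptor, yet the assay shows no readable difference, and no measured property of these groups is available to explain this result.

From the compounds shown here alone, a single step cannot show whether this position tolerates change in general, and whether a 4-aminophenyl group, a 4-carboxyphenyl group or a plain methyl on the same sulfonyl sulfur would give a step beyond the scatter remains open. Going by these compounds, it also remains open whether the same replacement would give a similar step on the core of compound 2, which carries 2,4-dichlorophenyl on its amine nitrogen.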